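Benzyl and phenyl amides in one cell assay

A few compounds are considered here, and "the series" means these few. Any claim that something is new, unique, unknown or untested is made for them only; others in the source may bear on it.

Values in a functional assay on CCRF-CEM cells (Homo sapiens) for inhibition, read by MTT assay, with a stated time of 72 h (a lower number here means a stronger inhibitor, a higher number a weaker inhibitor), for the series:
- compound 1 `C=C(Br)C(=O)Nc1cccc(/C=C/C(=O)Nc2ccc(F)cc2)c1`: 16600 nM
- compound 2 `C=C(Br)C(=O)Nc1cccc(/C=C/C(=O)Nc2cccc(F)c2)c1`: 26000 nM
- compound 3 `C=C(Br)C(=O)Nc1cccc(/C=C/C(=O)NCc2ccc(C)cc2)c1`: 550 nM
- compound 4 `C=C(Br)C(=O)Nc1cccc(/C=C/C(=O)Nc2ccc(OC)cc2)c1`: not yet measured

Compound 3 has the lowest number of the three, and its steps to both others lie beyond the scatter. It is the strongest inhibitor so far in this assay. The next change is 4-methoxyphenyl in place of 4-methylbenzyl on an amide-type nitrogen.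

Within the data shown here, two measured steps bear most directly on this change: a 30-fold lower number from compound 1 to compound 3 (1.48 log units; beyond the scatter) and a 47-fold lower number from compound 2 to compound 3 (1.67 log units; beyond the scatter). Both are large, and both end at the 4-methylbenzyl group. Compound 4 instead resembles compound 1 and compound 2 in carrying a substituted phenyl group on that nitrogen. The swap between those two fluorophenyl groups, a 1.6-fold higher number from compound 1 to compound 2 (0.19 log units; within the scatter), stays within the scatter. Among the measured compounds shown here, no measured compound carries 4-methoxyphenyl, and only compound 3 carries a benzyl group, so the basis is thin. A large step back toward a higher number is therefore expected, and the expected move is a 22-fold higher number from compound 3 to compound 4 (1.34 log units; beyond the scatter). For compound 4 the estimated value is 12000 nM, with an expected range from 4000 nM to 30000 nM.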

Compound 4, half-maximal inhibitory concentration: 26 nM
Beside the measured number, compound 4's estimate is 460-fold (2.66 log units) above it; measured number outside the range, below it.
By their numbers in this assay, from the lowest: compound 4; then compound 3; then compounds 1 and 2 (each within the scatter of the next).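

In this assay, a phenyl group on the amide-type nitrogen does not by itself go with weak inhibition: a 21-fold lower number from compound 3 to compound 4 (1.33 log units; beyond the scatter) puts the 4-methoxyphenyl group ahead of 4-methylbenzyl and makes compound 4 the strongest inhibitor of the four. The group on the phenyl ring carries far more weight than the swap between the two fluorophenyl groups suggested, with a 640-fold lower number from compound 1 to compound 4 (2.81 log units; beyond the scatter) for methoxy in place of fluoro on an aromatic carbon and a 1000-fold lower number from compound 2 to compound 4 (3.00 log units; beyond the scatter) for 4-methoxyphenyl in place of 3-fluorophenyl, while compound 1 and compound 2 remain within the scatter of each other. Nothing measured in this series gives a reason for these steps.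

The compounds shown leave open how a 4-hydroxyphenyl, 4-methylphenyl or 4-methoxybenzyl group on the same nitrogen would compare, so the separate parts played by the oxygen and by the benzyl carbon remain unresolved. They also leave open whether this order of compounds holds in any cell line or read-out other than this assay.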